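This account rests on a few compounds, and the source may have more. Where it says the series, first, only, none or still open, it means among the compounds named here.

Measured so far in a functional assay on HL-60 cells (Homo sapiens) for antiproliferative activity, with a stated time of 24 h; a lower number here means a stronger inhibitor, a higher number a weaker inhibitor:
compound 1, `NC(=O)c1c(NC(=O)c2ccccc2Cl)sc2c1CCN(C(=S)Nc1ccccc1C(F)(F)F)C2`, gives 10600 nM
compound 2, `COc1ccccc1NC(=S)N1CCc2c(sc(NC(=O)c3ccccc3Cl)c2C(N)=O)C1`, gives 40900 nM
compound 3, `NC(=O)c1c(NC(=O)c2ccccc2Cl)sc2c1CCN(C(=S)Nc1ccc(C(F)(F)F)cc1)C2`, gives 7590 nM

Compound 1 and compound 3 are built from the same atoms joined differently; the difference between the two cores is 4-(trifluoromethyl)phenyl in place of 2-(trifluoromethyl)phenyl on an amide-type nitrogen. The step of a 1.4-fold lower number from compound 1 to compound 3 (0.15 log units; within the scatter), so no order between these two is claimed. Compound 2 is derived from compound 1 by methoxy in place of trifluoromethyl on an aromatic carbon, and the step of a 3.9-fold higher number from compound 1 to compound 2 (0.59 log units; beyond the scatter). Between the two cores the same kind of substituent contrast appears again: the step of a 5.4-fold lower number from compound 2 to compound 3 (0.73 log units; beyond the scatter). Compound 3 carries the lowest number of the three, but only its gap to compound 2 lies beyond the scatter.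

Compound 4, `COc1ccc(NC(=S)N2CCc3c(sc(NC(=O)c4ccccc4Cl)c3C(N)=O)C2)cc1`, has not been measured. It is derived from compound 3 by methoxy in place of trifluoromethyl on an aromatic carbon. For the measured compounds named here, this is the same kind of change as the one from compound 1 to compound 2, not the same change: there the methoxy stands ortho to a large group, here it stands para to a large group. Going by the values given here, since the one measured instance of this exchange, a 3.9-fold higher number from compound 1 to compound 2 (0.59 log units; beyond the scatter), is the only guide, a step of similar direction is expected for compound 4, namely a 3.3-fold higher number from compound 3 to compound 4 (0.52 log units; beyond the scatter), with wide uncertainty because the place differs. Compound 4 is therefore estimated at 25000 nM in this assay, expected to fall between 9000 nM and 70000 nM.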

Compound 4, half-maximal inhibitory concentration: 15700 nM
Compound 4: middle estimate off by 1.6-fold (0.20 log units), on the high side; the range from low to high includes it.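

In this assay, methoxy in place of trifluoromethyl carries over from one core to the other in direction, and the two steps cannot be told apart in size: the same change on two cores in this assay, a 3.9-fold higher number (0.59 log units; beyond the scatter) from compound 1 to compound 2 and a 2.1-fold higher number (0.32 log units; beyond the scatter) from compound 3 to compound 4, 1.9-fold (0.27 log units) apart, within the scatter of two such steps

On the 4-substituted phenyl the exchange reads a 2.1-fold higher number from compound 3 to compound 4 (0.32 log units; beyond the scatter), the shift of the methoxy group reads a 2.6-fold lower number from compound 2 to compound 4 (0.42 log units; beyond the scatter), and a 1.5-fold higher number from compound 1 to compound 4 (0.17 log units; within the scatter) supports no order, leaving 2-methoxyphenyl with the highest number among the four. For the compounds shown here, this transfer rests on just two pairs, with the exchange seen only on the 2-substituted and 4-substituted phenyl groups; it shows agreement within this small set, not a constant step that could be relied on at other places on the ring or on other cores, and it gives no reason for the direction.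

The compounds shown leave open whether a chlorine, a nitrile or a dimethylamino group on the same phenyl ring would fall in line with methoxy and trifluoromethyl. They also leave open how the exchange would behave if the primary carboxamide gave way to a carboxylic acid, or if the 2-chlorophenyl group on the other amide gave way to an unsubstituted phenyl or a longer alkyl chain.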